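The compounds below may be only part of what the source reports. "The series", "measured", "known", "first", "only" and "open" are said of these compounds alone.

Working notes on the selenocyanate carbamate series.

The series is followed in a functional assay on CCRF-CEM cells (Homo sapiens) for cytotoxicity, read by MTT assay, with a stated time of 72 h; a lower number here means a stronger inhibitor of growth, a higher number a weaker inhibitor of growth. Compound 1 `COc1ccc(OC(=O)Nc2ccc([Se]C#N)cc2)cc1` gives 13000 nM there. Compound 2 `CCOC(=O)Nc1ccc([Se][Se]c2ccc(NC(=O)OCC)cc2)cc1`, which carries the diselenide in place of the selenocyanate and ethyl carbamates on both rings, gives 24600 nM. Compound 3 `C=CCOC(=O)Nc1ccc([Se]C#N)cc1`, the allyl carbamate, gives 9200 nM. On these three numbers compound 1 sits between the other two: the gap to compound 3 and the gap to compound 2 both lie within the usual scatter of repeated measurements, so no ordering among the three can be claimed.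

Compound 4 `N#C[Se]c1ccc(NC(=O)Oc2ccc(F)cc2)cc1` has not yet been measured in this assay. It differs from compound 1 by fluoro in place of methoxy on an aromatic carbon. The three measured compounds give no step that isolates a change of this kind, and nothing in the shown numbers points to a shift in either direction. A fluoro in place of a methoxy at a position remote from the selenocyanate is expected to leave the number close to that of compound 1, with no step beyond the scatter. The step from compound 1 to compound 4 is therefore estimated at a 1.2-fold lower number from compound 1 to compound 4 (0.07 log units; within the scatter). On that basis compound 4 is expected to give about 11000 nM in this assay, within a range of 4000 nM to 30000 nM.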

Compound 4, concentration for 50% growth inhibition: 12600 nM
Compound 4: middle estimate off by 1.1-fold (0.06 log units), on the low side; low and high end bracket the measured number.
By their numbers in this assay, from the lowest: compounds 3, 4, 1 and 2 (each within the scatter of the next, the first and the last beyond it).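

In this assay, among the compounds shown here, fluoro in place of methoxy on an aromatic carbon, para to a large group, gives a 1.0-fold lower number from compound 1 to compound 4 (0.01 log units; within the scatter), the first step that isolates a change in one place. At this position, therefore, the exchange of methoxy for fluoro, with one hydrogen-bond acceptor and one heavy atom fewer in the entering group, produces no difference that can be told from repeated measurement, although this rests on a single pair of compounds. No measurement of any property bears on this step, and the data give no account of it.

The compounds shown leave open whether an amine, a carboxylic acid or a longer chain such as butoxy at the same place would give a step beyond the scatter, since methoxy and fluoro are the only two groups compared there. For the compounds shown here, they also include no pair that changes the selenocyanate alone, so what that group contributes to the number cannot be read from them.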